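The compounds below may be only part of what the source reports. "The series", "measured", "known", "first", "only" and "open" are said of these compounds alone.

Compound 2 `O=S(=O)(c1cccc(F)c1)c1cnc2c(F)cccc2c1-c1cccc(F)c1` gives 1.14 mL/min in an ADME assay on microsomes from liver (Homo sapiens) for metabolic stability, tested at 2.5 uM (on this read-out higher numbers stand for fast clearance and lower numbers for slow clearance), the higher of the two numbers measured, while compound 1 `O=S(=O)(c1cccc(F)c1)c1cnc2c(F)cccc2c1-c1ccc(Cl)cc1` gives 0.62 mL/min; the step of a 1.8-fold higher number from compound 1 to compound 2 (0.26 log units; within the scatter) lies within the scatter. Compound 3 `COc1ccc(-c2c(S(=O)(=O)c3cccc(F)c3)cnc3c(F)cccc23)cc1` differs from compound 2 by 4-methoxyphenyl in place of 3-fluorophenyl on an aromatic carbon. Going by the values given here, the only measured step that bears on this change, a 1.8-fold higher number from compound 1 to compound 2 (0.26 log units; within the scatter), sits at the same carbon and stayed within the scatter, so no step beyond the scatter is expected here either. Compound 3 is therefore expected to give about 1.5 mL/min in this assay, with a range from 0.7 mL/min to 3.2 mL/min. That corresponds to an expected step of a 1.3-fold higher number from compound 2 to compound 3 (0.12 log units; within the scatter).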

Compound 3, intrinsic clearance in a liver preparation (reported as CLH), per the amount of preparation that the assay uses: 2.48 mL/min
For compound 3 the middle estimate is 1.7-fold (0.22 log units) below the measured one; measured number inside the range.
By their numbers in this assay, from the lowest: compounds 1 and 2 (each within the scatter of the next); then compound 3.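

At this aromatic carbon, this assay now shows a change beyond the scatter: 4-methoxyphenyl in place of 3-fluorophenyl gives a 2.2-fold higher number from compound 2 to compound 3 (0.34 log units; beyond the scatter). Methoxy in place of chloro on an aromatic carbon gives a 4.0-fold higher number from compound 1 to compound 3 (0.60 log units; beyond the scatter), so the group at this position can shift the number measurably, which the earlier pair did not show. Nothing available explains this rise. On these data alone, it remains open whether the higher number belongs to methoxy alone or would also appear with a hydroxy, an ethoxy or an amine on this phenyl ring.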